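Benzyl ether coumarin hydrazides: a bromo on the benzyl ring

This account rests on a few compounds, and the source may have more. Where it says the series, first, only, none or still open, it means among the compounds named here.

The series shares the core seen in compound 1 `CCOc1ccc2cc(C(=O)NN)c(=O)oc2c1`, which carries a methyl on the saturated chain carbon bound to the aromatic oxygen. In a functional assay on HeLa cells (Homo sapiens) for cytotoxicity, read by MTT assay, with a stated time of 72 h (a lower number here means a stronger inhibitor, a higher number a weaker inhibitor), compound 1 gives 38300 nM. Compound 2 `NNC(=O)c1cc2ccc(OCc3ccccc3)cc2oc1=O` carries a phenyl in place of that methyl, giving a benzyl ether. In this assay compound 2 gives > 100000 nM, which is a limit of the assay and not a number. The step of an at least 2.6-fold higher number from compound 1 to compound 2 (0.41 log units; beyond the scatter) is therefore known only as a lower bound. On the numbers shown, compound 2 sits at the weak end, at the limit of > 100000 nM in this assay, at which 1 of the 2 values shown sits.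

Compound 3 `NNC(=O)c1cc2ccc(OCc3cccc(Br)c3)cc2oc1=O` differs from compound 2 by bromo in place of hydrogen on an aromatic carbon. Going by the values given here, no measured step involves a bromo for hydrogen exchange, so the one step on record, an at least 2.6-fold higher number from compound 1 to compound 2 (0.41 log units; beyond the scatter), does not speak directly to it; it shows only that the benzyl ether already sits at the limit. Among the compounds with values here, with no measured precedent, no step beyond the scatter is expected in this assay in either direction, and compound 3 is expected to remain near the limit. The estimate for compound 3 in this assay is 100000 nM, in the range 40000 nM to 300000 nM. The expected step is a number no higher from compound 2 to compound 3 (the limit leaves the size open).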

Compound 3, half-maximal inhibitory concentration: > 100000 nM
Compound 3: no number, only a limit; the forecaster's own chance of this, stated with the estimate: 70%; the middle value sits exactly at the limit.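

In this assay compound 3 gives > 100000 nM, which is a limit of the assay and not a number. The step of an at least 2.6-fold higher number from compound 1 to compound 3 (0.41 log units; beyond the scatter) is again only a lower bound, and it shows that a 3-bromobenzyl on the aromatic oxygen, like the plain benzyl of compound 2, stays on the weak side of the short chain of compound 1. The step between compound 2 and compound 3 cannot be read because both values are limits, so the bromo in place of hydrogen on this aromatic carbon does not bring the benzyl ether under the limit, and the weak end of the series now holds more than one compound: the limit of > 100000 nM in this assay, at which 2 of the 3 values shown sit.

Going by these compounds, how far compound 2 and compound 3 each lie past the limit remains unknown, so the size and even the direction of any effect of the bromo stay hidden. Also open, on these data alone, is whether an amine or a carboxylic acid on the benzyl ring would bring a benzyl ether back to a readable value, and whether a longer chain in place of the benzyl would keep a readable value like that of compound 1.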